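Swapping a Halogenated Benzyl Group on a Triazole Arm

The compounds below may be only part of what the source reports. "The series", "measured", "known", "first", "only" and "open" are said of these compounds alone.

Compound 1 `COc1ccc(/C=C2\CN(C(=S)SCc3cn(Cc4ccccc4F)nn3)C/C(=C\c3ccc(OC)cc3)C2=O)cc1` and compound 2 `COc1ccc(/C=C2\CN(C(=S)SCc3cn(Cc4cccc(Cl)c4)nn3)C/C(=C\c3ccc(OC)cc3)C2=O)cc1` share one core and differ at a single place: 2-fluorophenyl in place of 3-chlorophenyl on a saturated chain carbon bound to an aromatic nitrogen. In a functional assay on 4T1 cells (Mus musculus) for cytotoxicity, read by MTT assay, with a stated time of 24 h (a higher number here means a weaker inhibitor, a lower number a stronger inhibitor), compound 2 gives 69700 nM, and compound 1 gives 49900 nM; the step between them is a 1.4-fold lower number from compound 2 to compound 1 (0.15 log units; within the scatter). Compound 3 `Cc1ccc(/C=C2\CN(Cc3cn(Cc4cccc(Cl)c4)nn3)C/C(=C\c3ccc(C)cc3)C2=O)cc1` is built on a different core, and the difference between the two cores is not broken down here; in this assay compound 3 gives 29300 nM. Compound 4 `Cc1ccc(/C=C2\CN(Cc3cn(Cc4ccccc4F)nn3)C/C(=C\c3ccc(C)cc3)C2=O)cc1` has not yet been measured and differs from compound 3 by the same change already seen from compound 2 to compound 1: 2-fluorophenyl in place of 3-chlorophenyl on a saturated chain carbon bound to an aromatic nitrogen. The place of the change is the same in both pairs. Because a 1.4-fold lower number from compound 2 to compound 1 (0.15 log units; within the scatter) stayed within the scatter, a similarly small movement is expected here, and the expected step from compound 3 to compound 4 in this assay is a 1.4-fold lower number from compound 3 to compound 4 (0.14 log units; within the scatter). For the measured compounds named here, with only one earlier example to lean on, the range is kept wide. Compound 4 is estimated at 21000 nM, with a likely span from 10000 nM to 45000 nM.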

Compound 4, half-maximal inhibitory concentration: 18000 nM
Compound 4: middle estimate off by 1.2-fold (0.07 log units), on the high side, within the range that was stated.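

In this assay, replacing 3-chlorobenzyl with 2-fluorobenzyl on the second core gives a 1.6-fold lower number from compound 3 to compound 4 (0.21 log units; within the scatter). Set beside the same change on the first core, this step tells the same story, a small movement on each core with no sign that the core alters it: the same change on two cores in this assay, a 1.4-fold lower number (0.15 log units; within the scatter) from compound 2 to compound 1 and a 1.6-fold lower number (0.21 log units; within the scatter) from compound 3 to compound 4, 1.2-fold (0.07 log units) apart, within the scatter of two such steps. This shows that the change carried over between these two cores without a large shift in the number, but both steps lie within the scatter, so it does not show that the change itself makes these compounds stronger inhibitors, and two pairs give no rule for other cores in the series.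

Going by these compounds, both pairs alter the halogen and its place on the ring at once, so what each of these contributes remains open, and 3-fluorobenzyl or 2-chlorobenzyl would separate the two. Also open, on these data alone, is how a plain benzyl group, or a benzyl group carrying an amine or a carboxylic acid, would behave at this spot.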